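A Chlorophenyl Swap on a Weakly Cytotoxic Series

This account rests on a few compounds, and the source may have more. Where it says the series, first, only, none or still open, it means among the compounds named here.

In a functional assay on HeLa cells (Homo sapiens) for cytotoxicity, read by ELISA, with a stated time of 4 days (a lower number here means a stronger inhibitor, a higher number a weaker inhibitor), compound 3 `Cc1ccc(-c2cc(-c3ccc(Cl)o3)cc(-c3ccc(Cl)s3)n2)cc1` gives only a limit, > 50000 nM, and not an exact number.

Compound 4 `Clc1cccc(-c2cc(-c3ccc(Cl)o3)cc(-c3ccc(Cl)s3)n2)c1` differs from it in one place: 3-chlorophenyl in place of 4-methylphenyl on an aromatic carbon. It has 3-chlorophenyl in place of 4-methylphenyl on an aromatic carbon, next to the ring nitrogen.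

Within the data shown here, no measured pair shows this swap alone. Still, compound 1 `Clc1cccc(-c2cc(-c3ccoc3)cc(-c3ccc(Cl)s3)n2)c1`, at 23700 nM, and compound 2 `Cc1ccsc1-c1cc(-c2ccc(Cl)o2)cc(-c2cccc(Cl)c2)n1`, at 24800 nM, both carry 3-chlorophenyl and give numbers within the usual scatter of each other, which suggests a similar reading for compound 4.

A modest step toward stronger inhibition is therefore expected, an at least 2.0-fold lower number from compound 3 to compound 4 (0.30 log units; that floor lies within the scatter).

For compound 4, the estimate is 25000 nM, with an expected range of 11000 nM to 50000 nM.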

Compound 4, half-maximal inhibitory concentration: 25200 nM
Compound 4: the middle estimate sits 1.0-fold (0.00 log units) below what was measured; measured number inside the range.
By their numbers in this assay, from the lowest: compounds 1, 2 and 4 (each within the scatter of the next). At a limit, above all of these: compound 3.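

Putting 3-chlorophenyl in place of 4-methylphenyl next to the ring nitrogen gives an at least 1.9-fold lower number from compound 3 to compound 4 (0.29 log units; that floor lies within the scatter) in this assay and turns a limit into an exact number. With 3-chlorophenyl kept, 5-chlorothiophen-2-yl in place of 3-methylthiophen-2-yl gives a 1.0-fold higher number from compound 2 to compound 4 (0.01 log units; within the scatter) and 5-chlorofuran-2-yl in place of furan-3-yl gives a 1.1-fold higher number from compound 1 to compound 4 (0.03 log units; within the scatter) so neither swap moves the reading beyond the scatter. Compound 3 gives only a limit, so the first step is a floor: the limit of > 50000 nM in this assay, at which 1 of the 4 values shown sits.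

Going by these compounds, how an amine, a carboxylic acid or a longer chain would read at this position stays open. So does the reading of 4-chlorophenyl there.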